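A few compounds are considered here, and "the series" means these few. Any claim that something is new, unique, unknown or untested is made for them only; others in the source may bear on it.

Compound 1 `CN1CCN(C(=O)c2c(NC(=O)NS(=O)(=O)c3ccccc3)sc3c2CCCCC3)CC1` gives 80200 nM in a functional assay on cells (Cancer cell lines, Homo sapiens) for inhibition, with a stated time of 48 h; on this read-out higher numbers stand for weaker inhibition of growth and lower numbers for stronger inhibition of growth.
Compound 3 `CCCCNC(=O)c1c(NC(=O)NS(=O)(=O)c2ccccc2)sc2c1CCCCC2` gives 92600 nM in this assay.
Compound 2 `O=C(Nc1sc2c(c1C(=O)NNc1ccc(Br)cc1)CCCCC2)NS(=O)(=O)c1ccccc1` gives > 100000 nM in this assay, which is a limit of the assay rather than a number.

All three share one core and differ only in the group attached to a carbonyl carbon. Of the two numbers, compound 3 and compound 1 lie within the scatter of each other, the step between them being a 1.2-fold higher number from compound 1 to compound 3 (0.06 log units; within the scatter). For compound 2 only a limit is known (the limit of > 100000 nM in this assay, at which 1 of the 3 values shown sits), so the steps of an at least 1.2-fold higher number from compound 1 to compound 2 (0.09 log units; that floor lies within the scatter) and an at least 1.0-fold lower number from compound 2 to compound 3 (0.03 log units; that floor lies within the scatter) set floors only, and both floors lie within the scatter.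

Compound 4 `O=C(Nc1sc2c(c1C(=O)N1CCN(c3ccccc3)CC1)CCCCC2)NS(=O)(=O)c1ccccc1` takes the next step: 4-phenylpiperazin-1-yl in place of butylamino on a carbonyl carbon. The measured exchanges at this same carbonyl carbon all stayed within the scatter, so from compound 3 to compound 4 no step beyond the scatter is expected in this assay, the estimated step being a 1.0-fold lower number from compound 3 to compound 4 (0.01 log units; within the scatter). Compound 4 is therefore expected at about 90000 nM, within a range from 40000 nM to 200000 nM.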

Compound 4, concentration for 50% growth inhibition: 60300 nM
For compound 4 the middle estimate is 1.5-fold (0.17 log units) above the measured one; low and high end bracket the measured number.
By their numbers in this assay, from the lowest: compounds 4, 1 and 3 (each within the scatter of the next). At a limit, above all of these: compound 2.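

Placing 4-phenylpiperazin-1-yl on the carbonyl carbon adds two rings and removes the hydrogen-bond donor of butylamino, yet the step is a 1.5-fold lower number from compound 3 to compound 4 (0.19 log units; within the scatter) in this assay and so does not separate the two compounds. Phenyl in place of methyl on the amine nitrogen in a ring, the smallest exchange seen so far at this carbonyl group, gives a 1.3-fold lower number from compound 1 to compound 4 (0.12 log units; within the scatter) and likewise stays inside the usual variation between repeats. The step of an at least 1.6-fold lower number from compound 2 to compound 4 (0.21 log units; that floor lies within the scatter) sets only a floor, since the first compound in it stands at a limit of the assay, not a number: the limit of > 100000 nM in this assay, at which 1 of the 4 values shown sits.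

No exchange shown here gives a step beyond the scatter. As far as these compounds go, whether a carboxylic acid or a longer chain on this carbonyl carbon would do so stays open, as does the effect of any change elsewhere on the shared core.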